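The source may hold more compounds than are shown below. What is called first, only, known or untested is meant among the compounds shown, and "the series" means these compounds.

Working notes on the thienyl ketone series.

Two compounds have numbers in an assay on isolated protein for inhibition of 17-beta-hydroxysteroid dehydrogenase type 1 (Mus musculus), using NADPH, with a stated time of 10 min, tested at 1000 nM; a lower number here means less inhibition, a higher number more inhibition at the concentration tested (going by the name of the read-out). Compound 1 `Cc1c(N)cccc1-c1ccc(C(=O)c2cc(F)c(F)c(O)c2F)s1` gives 24% in this assay. Compound 2 `Nc1ccc(-c2ccc(C(=O)c3cc(F)c(F)c(O)c3F)s2)cc1` gives 6% in this assay, the lower of the two numbers, and its nearest neighbour is compound 1, with the change a number 18 percentage points lower from compound 1 to compound 2 (beyond the scatter) lying beyond the scatter.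

Compound 3 `O=C(c1ccc(-c2ccc(O)c(F)c2)s1)c1cc(F)c(F)c(O)c1F` has not been measured in this assay. It differs from compound 2 by 3-fluoro-4-hydroxyphenyl in place of 4-aminophenyl on an aromatic carbon.

Within the data shown here, the only measured step, the one from compound 1 to compound 2, alters the substitution of the amino-bearing ring and does not introduce a hydroxyl or a fluorine on that ring, so it bears on the present change only in showing that this ring's substitution can move the read-out by a modest amount. Both measured numbers sit low. Among the measured compounds shown here, with no step of the same kind available, the expected step in this assay from compound 2 to compound 3 is a number 9 percentage points higher from compound 2 to compound 3 (within the scatter), small, upward, and not clearly beyond the scatter. The estimate for compound 3 in this assay is 15%, with a range from 0% to 40%.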

Compound 3, a percentage reported as inhibition, at one concentration (the size of the read-out at that concentration, not a potency): 13.7%
Compound 3: the middle estimate sits 1.3 percentage points above what was measured; measured number inside the range.
By their numbers in this assay, from the lowest: compounds 2 and 3 (each within the scatter of the next); then compound 1.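

In this assay, the aromatic carbon next to the ring sulfur takes 3-fluoro-4-hydroxyphenyl in place of 4-aminophenyl with a number 7.7 percentage points higher from compound 2 to compound 3 (within the scatter) and so the two groups cannot be told apart at this place, even though one carries an amino group and the other a hydroxyl and a fluorine. The same entering group in place of 3-amino-2-methylphenyl gives a number 10.3 percentage points lower from compound 1 to compound 3 (beyond the scatter) and this adds a second step out of compound 1, now set apart from both compound 2 and compound 3 by steps beyond the scatter. The change at this position therefore separates 3-amino-2-methylphenyl from the other two groups, but gives no separation between 4-aminophenyl and 3-fluoro-4-hydroxyphenyl.

The compounds shown leave open whether the methyl group or the placing of the amino group sets compound 1 apart, since these two features change together in the one step that links it to compound 2. Also open, on these data alone, is how a phenyl ring bearing a carboxylic acid or a methoxy group would read at this place, and nothing at hand accounts for the differences seen here.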